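This account rests on a few compounds, and the source may have more. Where it says the series, first, only, none or still open, it means among the compounds named here.

Measured compounds in a functional assay on BT-549 cells (Homo sapiens) for cytotoxicity, read by sulforhodamine B assay, with a stated time of 48 h; on this read-out higher numbers stand for lower toxicity in this test and lower numbers for higher toxicity in this test:
compound 1 `ClCc1ccccc1Cn1cnc2c(Cl)ncnc21` — 20000 nM
compound 2 `ClCc1cccc(Cn2cnc3ncnc(Cl)c32)c1` — 63100 nM
compound 3 `ClCc1cccc(Cn2cnc3c(Cl)nc(Cl)nc32)c1` — 6160 nM

Compound 2 gives the highest number of the three in this assay; compound 1 sits nearest to it with a lower number, and compound 3 sits furthest, also lower, both gaps beyond the scatter. Compound 4 `ClCc1cccc(Cn2cnc3nc(Cl)nc(Cl)c32)c1` is not yet measured. It differs from compound 2 by chloro in place of hydrogen on an aromatic carbon. No measured pair isolates this change, so its effect in this assay is not known from the shown compounds; the expectation is a step toward lower numbers, beyond the scatter, with the size uncertain. Compound 4 is therefore estimated at 12000 nM, with a range from 4000 nM to 40000 nM, a step of a 5.3-fold lower number from compound 2 to compound 4 (0.72 log units; beyond the scatter) expected.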

Compound 4, concentration lethal to 50% of the cells: 4160 nM
Estimate against measurement, compound 4: 2.9-fold (0.46 log units) above, and the stated range covers the measured number.
By their numbers in this assay, from the lowest: compounds 4 and 3 (each within the scatter of the next); then compound 1; then compound 2.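

In this assay, going by these compounds alone, chloro in place of hydrogen on an aromatic carbon between two ring nitrogen atoms gives a 15-fold lower number from compound 2 to compound 4 (1.18 log units; beyond the scatter), a large step and the first comparison that differs in one place. This position, meta to a chloro group, is therefore not silent: a single added chlorine moves the number toward higher toxicity in this test. Nothing measured here bears on the reason for the step. Going by these compounds, whether an amine or a methoxy group at this position would move the number the same way stays open, as does whether the step holds without the other chloro group.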